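Ether side-chain changes on a shared core

The source may hold more compounds than are shown below. What is called first, only, known or untested is meant among the compounds shown, and "the series" means these compounds.

In an assay on cells with melanin-concentrating hormone receptor 1 (Homo sapiens) as the target, read by radioligand binding (on this read-out higher numbers stand for weaker inhibition and lower numbers for stronger inhibition), compound 1 `Nc1ccc2cccc(OCCC3CCCCC3)c2n1` gives 808 nM, and compound 3 `CC(COC(C)(C)C)Oc1cccc2ccc(N)nc12` gives 306 nM. Compound 2 `Nc1ccc2cccc(OCC3CCCO3)c2n1` reaches only the assay limit of > 2000 nM, so its true position among the three is not known (the limit of > 2000 nM in this assay, at which 1 of the 3 values shown sits). Compound 4 `CC1CC1COc1cccc2ccc(N)nc12` has not yet been measured; it differs from compound 2 by 2-methylcyclopropyl in place of oxolan-2-yl on a saturated chain carbon bound to an oxygen on an aromatic ring. Among the compounds with values here, no step between two measured compounds is available, so the size of the move must be judged from the three numbers alone. An expected step toward stronger inhibition, an at least 2.0-fold lower number from compound 2 to compound 4 (0.30 log units; that floor lies within the scatter), is taken for this assay. Compound 4 is estimated at 1000 nM, with a range from 300 nM to 3000 nM.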

Compound 4, half-maximal inhibitory concentration: 1640 nM
Estimate against measurement, compound 4: 1.6-fold (0.21 log units) below, and the stated range covers the measured number.
By their numbers in this assay, from the lowest: compound 3; then compound 1; then compound 4. At a limit, above all of these: compound 2.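

Within the data shown here, replacing oxolan-2-yl with 2-methylcyclopropyl on a saturated chain carbon bound to an oxygen on an aromatic ring gives the first readable step: in this assay the change gives an at least 1.2-fold lower number from compound 2 to compound 4 (0.08 log units; that floor lies within the scatter). Compound 2 gives only a limit of the assay, not a number: the limit of > 2000 nM in this assay, at which 1 of the 4 values shown sits. With the three-membered carbon ring in place, compound 4 gives a measured 1640 nM.

Going by these compounds, the true size of the step stays open, as only its floor is known. Also open, on these data alone, is how plain cyclopropyl or an amine would read at this place.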